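Acyl swap on the compound 3 amide: neopentyl for isopropyl

This account rests on a few compounds, and the source may have more. Where it says the series, first, only, none or still open, it means among the compounds named here.

Values in a physicochemical assay for solubility; on this read-out higher numbers stand for higher solubility and lower numbers for lower solubility:
- compound 1 `O=C(CN1CCCC1)N1CCC(NS(=O)(=O)c2cc(S(=O)(=O)c3ccccc3)ccc2C(F)(F)F)CC1`: 25000 nM
- compound 2 `O=C(CN1CCNCC1)N1CCC(NS(=O)(=O)c2cc(S(=O)(=O)c3ccccc3)ccc2C(F)(F)F)CC1`: 50000 nM
- compound 3 `CC(C)C(=O)N1CCC[C@H]1C(=O)N1CCC(NS(=O)(=O)c2cc(S(=O)(=O)c3ccccc3)ccc2C(F)(F)F)CC1`: 100000 nM

Compound 3 stands clear of compound 1 only: the data show a 4.0-fold higher number from compound 1 to compound 3 (0.60 log units; beyond the scatter), but also a 2.0-fold higher number from compound 2 to compound 3 (0.30 log units; within the scatter). Compound 4 `CC(C)(C)CC(=O)N1CCC[C@H]1C(=O)N1CCC(NS(=O)(=O)c2cc(S(=O)(=O)c3ccccc3)ccc2C(F)(F)F)CC1` differs from compound 3 as follows: neopentyl in place of isopropyl on a carbonyl carbon. For the measured compounds named here, no measured step exchanges only this alkyl group. The nearest, a 4.0-fold higher number from compound 1 to compound 3 (0.60 log units; beyond the scatter) and a 2.0-fold higher number from compound 2 to compound 3 (0.30 log units; within the scatter), replace the whole group on the carbonyl carbon and give no direction for this change. In this assay, no step beyond the scatter is therefore expected, with a slight lean towards a lower number. The expected step is a 2.0-fold lower number from compound 3 to compound 4 (0.30 log units; within the scatter). The estimated value for compound 4 is 50000 nM, with an expected range from 15000 nM to 100000 nM.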

Compound 4, solubility: 25000 nM
Estimate against measurement, compound 4: 2.0-fold (0.30 log units) above; the range from low to high includes it.
By their numbers in this assay, from the lowest: compounds 1, 4, 2 and 3 (each within the scatter of the next, the first and the last beyond it).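

In this assay, for the compounds shown here, the alkyl group on this carbonyl carbon matters on its own: neopentyl in place of isopropyl gives a 4.0-fold lower number from compound 3 to compound 4 (0.60 log units; beyond the scatter), the first step that changes only this group. With neopentyl, the lead of the 1-(acyl)pyrrolidin-2-yl series over the (pyrrolidin-1-yl)methyl and (piperazin-1-yl)methyl compounds is gone, with a 2.0-fold lower number from compound 2 to compound 4 (0.30 log units; within the scatter) and no change at the digits printed from compound 1 to compound 4 (within the scatter). Nothing measured here accounts for the step.

Open, from the compounds shown here alone, is whether the step follows chain length or branching, which an unbranched butyl chain would help separate. A carboxylic acid or a terminal amine on this carbonyl carbon also remains unread.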